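The source may hold more compounds than are shown below. What is called first, only, known or untested is meant among the compounds shown, and "the series" means these compounds.

Measured in an assay on FRT-Jurkat cells for inhibition of nuclear factor NF-kappa-B complex (Homo sapiens), read by flow cytometry, with a stated time of 24 h, tested at 10 uM; a higher number here means more inhibition at the concentration tested (going by the name of the read-out), a lower number less inhibition:

compound 1 `O=C1CCC(N2C(=O)c3ccc(Nc4ccc(O)cc4)cc3C2=O)C(=O)N1` gives 4%
compound 2 `CC(=O)c1ccc(Nc2ccc3c(c2)C(=O)N(C2CCC(=O)NC2=O)C3=O)cc1` gives -2%
compound 3 `CC(=O)c1ccc(Nc2cccc3c2C(=O)N(C2CCC(=O)NC2=O)C3=O)cc1` gives 2%

All three numbers sit close to zero and close to one another. Compound 2 and compound 3 are built from the same atoms joined differently; the difference between the two cores is not broken down here, and their two values show no separation that exceeds the scatter. From compound 2 to compound 1 the change is hydroxy in place of acetyl on an aromatic carbon, and it yields a number 6 percentage points higher from compound 2 to compound 1 (within the scatter).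

Compound 4 `O=C1CCC(N2C(=O)c3cccc(Nc4ccc(O)cc4)c3C2=O)C(=O)N1` is not yet measured. It stands to compound 3 as compound 1 stands to compound 2: the change is hydroxy in place of acetyl on an aromatic carbon, the same change at the same kind of place, on the core of compound 3 rather than that of compound 2. Going by the values given here, the step expected from compound 3 to compound 4 is a number 4 percentage points higher from compound 3 to compound 4 (within the scatter), which rests on the single earlier instance of this change, a number 6 percentage points higher from compound 2 to compound 1 (within the scatter), a step inside the scatter. For compound 4 the estimate is 6%, with a range from -8% to 20%, a number close to zero like the measured three.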

Compound 4, a percentage reported as inhibition, at one concentration (the size of the read-out at that concentration, not a potency): 4%
For compound 4 the middle estimate is 2 percentage points above the measured one; the measured number falls inside the stated range.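

In this assay, hydroxy in place of acetyl on an aromatic carbon gives a number 2 percentage points higher from compound 3 to compound 4 (within the scatter). Set beside the earlier instance, the change reads the same on both cores: the same change on two cores in this assay, a number 6 percentage points higher (within the scatter) from compound 2 to compound 1 and a number 2 percentage points higher (within the scatter) from compound 3 to compound 4, 4 percentage points apart, within the scatter of two such steps

This agreement is only that of two steps that cannot be told from scatter, with all the compounds shown reading close to zero, so it does not show that the change does anything on either core, nor that it would carry over to a compound with a reading clearly away from zero.

Still open, on these data alone, is whether an amine, a carboxylic acid or a methoxy group in place of the acetyl or hydroxy, on either core, would give a reading that stands clear of the scatter. Going by these compounds alone, each compound here also has only a single reading at one concentration, so the series leaves open any comparison of potency.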